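The source may report more compounds than this note shows. Statements on the series, on what has been measured and on what is new or still open speak of the compounds shown alone.

The shared core carries a sulfonamide on one side and a second substituent on the other, and two members of this series have been measured so far. Compound 1, `COc1cc2nc(N3CCCC3)nc(NS(=O)(=O)c3ccc(C)cc3)c2cc1OC`, gives 7.06 ug/mL in a functional assay on THP-1 cells (Homo sapiens) for cytotoxicity, read by MTT assay, with a stated time of 24 h; on this read-out lower numbers stand for stronger inhibition and higher numbers for weaker inhibition. Compound 2, `COc1ccc(S(=O)(=O)Nc2nc(Cl)nc3cc(OC)c(OC)cc23)cc1C`, gives 79 ug/mL in this assay, the higher of the two numbers, and its nearest neighbour on this read-out is compound 1, which stands well beyond the usual scatter from it; since the two differ in more than one place, only their two values can be compared.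

Compound 3, `COc1cc2nc(Cl)nc(NS(=O)(=O)c3ccc(C)cc3)c2cc1OC`, is not yet measured. It differs from compound 2 in one place: 4-methylphenyl in place of 4-methoxy-3-methylphenyl on a sulfonyl sulfur. The same 4-methylphenyl on the sulfonyl sulfur is present in compound 1, which gives 7.06 ug/mL, although compound 1 also differs from compound 3 elsewhere. Compound 3 is therefore expected to give a somewhat lower number than compound 2, a step of a 2.3-fold lower number from compound 2 to compound 3 (0.35 log units; beyond the scatter) of modest size, perhaps only at the edge of the scatter. The estimate for compound 3 in this assay is 35 ug/mL, within a range from 10 ug/mL to 110 ug/mL.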

Compound 3, half-maximal inhibitory concentration: 33.5 ug/mL
Estimate against measurement, compound 3: 1.0-fold (0.02 log units) above, within the range that was stated.
By their numbers in this assay, from the lowest: compound 1; then compound 3; then compound 2.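

Going by these compounds alone, with compound 3 in place, the two earlier compounds are linked through single changes for the first time. In this assay, 4-methylphenyl in place of 4-methoxy-3-methylphenyl on the sulfonyl sulfur, with the chloro kept, gives a 2.4-fold lower number from compound 2 to compound 3 (0.37 log units; beyond the scatter), so the group on the sulfonyl sulfur alone moves the number beyond the scatter, although the step is modest. Chloro in place of pyrrolidin-1-yl on an aromatic carbon, with 4-methylphenyl kept, gives a 4.7-fold higher number from compound 1 to compound 3 (0.68 log units; beyond the scatter), which shows that this second place also matters on its own. No measurement here bears on why either change shifts the number.

The compounds shown do not tell whether the methoxy or the methyl of the leaving group accounts for the first step, which a plain 4-methoxyphenyl or 3-methylphenyl on the sulfonyl sulfur would help to separate. Going by these compounds, it also remains open whether other amines in place of pyrrolidin-1-yl, such as morpholine or dimethylamine, would give a similar step, and whether the two changes simply add up.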